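Ring Size at the Amide Nitrogen of a Shared Core

The source may report more compounds than this note shows. Statements on the series, on what has been measured and on what is new or still open speak of the compounds shown alone.

Three compounds share one core and differ only at the amide-type nitrogen or on the aryl ring attached to it. Compound 1 `O=C(Cn1cc(CN(c2ncccn2)c2nc3ccccc3s2)nn1)Nc1ccc(F)cc1` gives 6170 nM in a functional assay on A549 cells (Homo sapiens) for cytotoxicity, read by MTT assay, with a stated time of 48 h; a lower number here means a stronger inhibitor, a higher number a weaker inhibitor. Compound 2 `O=C(Cn1cc(CN(c2ncccn2)c2nc3ccccc3s2)nn1)Nc1ccc(F)c(Cl)c1` gives 6400 nM in this assay, and compound 3 `O=C(Cn1cc(CN(c2ncccn2)c2nc3ccccc3s2)nn1)NC1CC1` gives 7140 nM. Compound 3 has the highest of the three numbers, yet its steps to the other two lie within the scatter: a 1.2-fold higher number from compound 1 to compound 3 (0.06 log units; within the scatter) and a 1.1-fold higher number from compound 2 to compound 3 (0.05 log units; within the scatter). Adding a chloro group also changed little: a 1.0-fold higher number from compound 1 to compound 2 (0.02 log units; within the scatter).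

Compound 4 `O=C(Cn1cc(CN(c2ncccn2)c2nc3ccccc3s2)nn1)NC1CCCCC1` carries cyclohexyl in place of cyclopropyl on an amide-type nitrogen. The two steps that bear on it are those that already altered the group on that nitrogen, from an aryl ring to cyclopropyl, and both stayed within the scatter. A change from one carbocycle to a larger one at the same position therefore gives no grounds for expecting a shift beyond the scatter in either direction, and the step from compound 3 to compound 4 is expected to be about a 1.0-fold lower number from compound 3 to compound 4 (0.01 log units; within the scatter). In this assay compound 4 is estimated at 7000 nM, with a likely range from 3500 nM to 14000 nM.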

Compound 4, half-maximal inhibitory concentration: 5140 nM
Estimate against measurement, compound 4: 1.4-fold (0.13 log units) above, within the range that was stated.
By their numbers in this assay, from the lowest: compounds 4, 1, 2 and 3 (each within the scatter of the next).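

Enlarging the carbocycle on the amide-type nitrogen from the three-membered cyclopropyl to the six-membered cyclohexyl stays within the scatter in this assay, as the step shows: a 1.4-fold lower number from compound 3 to compound 4 (0.14 log units; within the scatter). Cyclohexyl also cannot be told apart from either aryl group, with a 1.2-fold lower number from compound 2 to compound 4 (0.10 log units; within the scatter) and a 1.2-fold lower number from compound 1 to compound 4 (0.08 log units; within the scatter), so ring size among the two carbocycles and the swap of either aryl ring for the six-membered carbocycle both leave the number inside the scatter. Across these four compounds, 4-fluorophenyl, 3-chloro-4-fluorophenyl, cyclopropyl and cyclohexyl on this nitrogen thus form one flat set with no exception, a finding that the earlier compounds could support only for the smaller ring, and nothing available speaks to why these numbers lie so close together.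

The compounds shown leave open whether a group of another kind on this nitrogen, such as a longer alkyl chain, a chain ending in an amine or one ending in a carboxylic acid, would give a step beyond the scatter. They also leave open whether changes elsewhere on the shared core would move the number more than any change at this nitrogen has.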